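Halogen and alkyl exchange on the benzyl group of the series

This account rests on a few compounds, and the source may have more. Where it says the series, first, only, none or still open, it means among the compounds named here.

Measured compounds:
- compound 1 `COc1ccc(Cn2c(NCCNC(=N)N)nc(=O)n(Cc3ccc([N+](=O)[O-])cc3)c2=O)cc1` gives 0.048 nM in a functional assay on the whole organism (strain C57Bl/6) for inhibition, with Mus musculus as the target, with a stated time of 180 min, at 48 degrees C; a higher number here means that more compound is needed for the effect, a lower number that less compound is needed
- compound 2 `COc1ccc(Cn2c(NCCNC(=N)N)nc(=O)n(Cc3ccc(Br)cc3)c2=O)cc1` gives 0.00036 nM in this assay
- compound 3 `COc1ccc(Cn2c(NCCNC(=N)N)nc(=O)n(Cc3ccc(Cl)cc3)c2=O)cc1` gives 0.004 nM in this assay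

Compound 3 stands second highest of the three numbers in this assay, apart from compound 2 by an 11-fold higher number from compound 2 to compound 3 (1.05 log units; beyond the scatter) and from compound 1 by a 12-fold lower number from compound 1 to compound 3 (1.08 log units; beyond the scatter). The change to compound 4 `CCc1ccc(Cn2c(=O)nc(NCCNC(=N)N)n(Cc3ccc(OC)cc3)c2=O)cc1` is ethyl in place of chloro on an aromatic carbon.

Among the compounds with values here, no measured step replaces a halogen by an alkyl group, so none bears directly on this change. The steps seen are a 130-fold lower number from compound 1 to compound 2 (2.12 log units; beyond the scatter), a 12-fold lower number from compound 1 to compound 3 (1.08 log units; beyond the scatter) and an 11-fold higher number from compound 2 to compound 3 (1.05 log units; beyond the scatter); they show that swapping the group at this place moves the number by large amounts in either direction, and that two groups of similar kind still differ beyond the scatter. For ethyl there is no reference point, so a step of either sign cannot be excluded.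

Compound 4 is therefore expected near compound 3, with a wide range on both sides: 0.006 nM, from 0.0008 nM to 0.05 nM. The step this estimate implies is a 1.5-fold higher number from compound 3 to compound 4 (0.18 log units; within the scatter), expected to lie within the scatter.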

Compound 4, half-maximal effective concentration: 0.0058 nM
Beside the measured number, compound 4's estimate is 1.0-fold (0.01 log units) above it; low and high end bracket the measured number.
By their numbers in this assay, from the lowest: compound 2; then compounds 3 and 4 (each within the scatter of the next); then compound 1.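

In this assay, within the data shown here, the exchange of 4-chlorobenzyl for 4-ethylbenzyl gives a 1.5-fold higher number from compound 3 to compound 4 (0.16 log units; within the scatter), the first step at this position that does not go beyond the scatter, so ethyl, with two heavy atoms, cannot be told apart from chloro, with one. Ethyl also sits apart from the other two groups, with a 16-fold higher number from compound 2 to compound 4 (1.21 log units; beyond the scatter) and an 8.3-fold lower number from compound 1 to compound 4 (0.92 log units; beyond the scatter), which leaves compound 2, the bromo compound, with the lowest number of the four and compound 1, the nitro compound, with the highest; the place therefore does not simply separate halogens from the alkyl group, as chloro and bromo differ beyond the scatter while chloro and ethyl do not. No measurement at hand explains this ordering.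

Open, as far as these compounds go, is whether iodo would follow bromo, and whether methyl, propyl or a longer chain would stay with ethyl or move away from it. An amine or a carboxylic acid at this position also remains to be placed against these numbers, as does any exchange of the methoxy group on the other benzyl group.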